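The compounds below may be only part of what the source reports. "The series", "measured", "known", "first", "only" and "open" are said of these compounds alone.

Values in a physicochemical assay for solubility, read by nephelometry, measured as kinetic solubility, with a stated time of 30 min (on this read-out lower numbers stand for lower solubility and higher numbers for higher solubility), both of them limits:
- Compound 1 `CC(C)(O)CNCCCOc1ccc([C@H]2CC[C@]3(CC2)OOC2(O3)C3CC4CC(C3)CC2C4)cc1`: > 100 ug/mL, a limit
- Compound 2 `CS(=O)(=O)N1CCN(CCCOc2ccc([C@H]3CC[C@]4(CC3)OOC3(O4)C4CC5CC(C4)CC3C5)cc2)CC1`: < 1.6 ug/mL, a limit

Compound 2 stands at the limit of < 1.6 ug/mL in this assay, at which 1 of the 2 values shown sits. Compound 3 `CC1(C)CC(O)(COc2ccc([C@H]3CC[C@]4(CC3)OOC3(O4)C4CC5CC(C4)CC3C5)cc2)CC(C)(C)N1` carries 4-hydroxy-2,2,6,6-tetramethylpiperidin-4-yl in place of 2-(4-(methylsulfonyl)piperazin-1-yl)ethyl on a saturated chain carbon bound to an oxygen on an aromatic ring. Among the compounds with values here, one measured step bears on this: an at least 62-fold lower number from compound 1 to compound 2 (1.79 log units; beyond the scatter), a large step that introduced the 4-(methylsulfonyl)piperazin-1-yl group. Compound 3 lacks that group, so a move in the opposite direction is expected in this assay, beyond the scatter. The expected step is an at least 25-fold higher number from compound 2 to compound 3 (1.39 log units; beyond the scatter). For compound 3 the estimate is 40 ug/mL, with a range of 6.3 ug/mL to 100 ug/mL.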

Compound 3, solubility: > 100 ug/mL
Compound 3: a limit, no number; the forecaster's own chance of this, stated with the estimate: 30%; middle value at least 2.5-fold (0.39 log units) away from the limit.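

At the saturated chain carbon bound to an oxygen on an aromatic ring, 4-hydroxy-2,2,6,6-tetramethylpiperidin-4-yl in place of 2-(4-(methylsulfonyl)piperazin-1-yl)ethyl gives an at least 62-fold higher number from compound 2 to compound 3 (1.79 log units; beyond the scatter) in this assay. Compound 3 gives > 100 ug/mL, a limit. The top of the range is therefore not confined to the open (2-hydroxy-2-methylpropyl)amino chain of compound 1: the limit of > 100 ug/mL in this assay, at which 2 of the 3 values shown sit.

The steps between compound 1 and compound 3 cannot be read, as both values are limits. On these data alone, whether an unsubstituted piperazin-1-yl chain at this place would read like compound 2 or like compound 3 stays open.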